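The compounds below may be only part of what the source reports. "The series", "measured", "known", "first", "only" and "open" are said of these compounds alone.

Measured so far:
compound 1 `Cc1nc(C)c(CNC(=O)CN2CCCC2=O)nc1C`: 1200000 nM
compound 2 `Cc1nc(C)c(CSc2nnc(-c3cccs3)n2N)nc1C`: 810000 nM

In a functional assay on a cell-free system (Platelet, plasma, Oryctolagus cuniculus) for inhibition, with a stated time of 5 min (a higher number here means a weaker inhibitor, a lower number a stronger inhibitor), compound 2 gives 810000 nM, and compound 1 gives 1200000 nM. These two numbers lie within the usual scatter of each other, so they cannot be told apart, and both are very large numbers on this scale.

Compound 3 `Cc1nc(C)c(CSc2nnc(-c3ccco3)n2N)nc1C` keeps all of compound 2 except one group, with furan-2-yl in place of thiophen-2-yl on an aromatic carbon. That carbon belongs to a five-membered aromatic ring with 3 nitrogen. For the measured compounds named here, no measured pair shows this kind of swap, so the data offer no direct guide, and no change beyond the scatter is expected in this assay, in either direction. The expected step is a 1.1-fold higher number from compound 2 to compound 3 (0.05 log units; within the scatter). Compound 3 is estimated at 900000 nM, with an expected range of 400000 nM to 2000000 nM.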

Compound 3, half-maximal inhibitory concentration: 940000 nM
Estimate against measurement, compound 3: 1.0-fold (0.02 log units) below; measured number inside the range.
By their numbers in this assay, from the lowest: compounds 2, 3 and 1 (each within the scatter of the next).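

In this assay the exchange of thiophen-2-yl for furan-2-yl on this aromatic carbon gives a 1.2-fold higher number from compound 2 to compound 3 (0.06 log units; within the scatter) and provides the only pair shown that differs in one place. At this position, then, replacing the sulfur of the five-membered aromatic ring with oxygen, with the same count of heavy atoms, causes no change that this assay can distinguish. Nothing available here offers an explanation for this result.

On these data alone, all three numbers remain very large on this scale, so it is unknown whether any group on this carbon can shift the number beyond the scatter. How a phenyl ring, a longer alkyl chain or a carboxylic acid at this place would read in this assay is open, as is the effect of changing the amino group.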